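The source may hold more compounds than are shown below. What is called first, only, known or untested is meant among the compounds shown, and "the series" means these compounds.

Measured in a functional assay on SMMC-7721 cells (Homo sapiens) for inhibition, read by CCK-8 assay, with a stated time of 72 h, tested at 8 uM; a lower number here means less inhibition of growth, a higher number more inhibition of growth at the concentration tested:
- compound 1 `Nc1ccccc1NC(=O)/C=C/c1ccc(CSc2ccc(Cl)cc2)cc1`: 16.5%
- compound 2 `Cc1ccc(SCc2ccc(C(=O)Nc3ccccc3N)cc2)cc1`: 82.7%

Compound 1 holds the lower of the two numbers, and compound 2 lies higher, beyond the scatter. Compound 3 `Nc1ccccc1NC(=O)/C=C/c1ccc(CSc2cccc3ccccc23)cc1` has naphthalen-1-yl in place of 4-chlorophenyl on a sulfur. Going by the values given here, no measured pair shows what a single change does here, so the expectation stays close to compound 1 at 16.5%, with no step beyond the scatter in this assay. The expected change is a number 5.5 percentage points higher from compound 1 to compound 3 (within the scatter). For compound 3 the estimated value is 22%, with an expected range of 6% to 48%.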

Compound 3, percent growth inhibition at one concentration: 18.3%
Beside the measured number, compound 3's estimate is 3.7 percentage points above it; the range from low to high includes it.
By their numbers in this assay, from the lowest: compounds 1 and 3 (each within the scatter of the next); then compound 2.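

In this assay this first single-place comparison gives a number 1.8 percentage points higher from compound 1 to compound 3 (within the scatter) and so 4-chlorophenyl and naphthalen-1-yl on the sulfur cannot be told apart at the concentration tested. A second aromatic ring in place of the chlorine-bearing single ring thus makes no readable difference to growth inhibition here. Nothing available explains this result. Still open, on these data alone, is whether a 4-aminophenyl or a 4-carboxyphenyl group on that sulfur would read differently. Also open, as far as these compounds go, is whether the same swap would behave alike on another core.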